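This account rests on a few compounds, and the source may have more. Where it says the series, first, only, none or still open, it means among the compounds named here.

Compound 1 `O=S(=O)(NCCCNc1nccc(-c2c(-c3cccc(F)c3)nc3sccn23)n1)c1ccc(F)cc1` gives > 20000 nM in a functional assay on SK-MEL-28 cells (Homo sapiens) for cytotoxicity, read by MTT assay (on this read-out higher numbers stand for weaker inhibition and lower numbers for stronger inhibition), which is a limit of the assay rather than a number.
Compound 2 `O=S(=O)(NCCNc1nccc(-c2c(-c3cccc(F)c3)nc3sccn23)n1)c1ccc(Cl)cc1` gives 18600 nM in this assay.

Within the data shown here, compound 2 thus stands as the only measured number in this assay; the other value shown is a limit, (the limit of > 20000 nM in this assay, at which 1 of the 2 values shown sits). Compound 3 `O=S(=O)(NCCCNc1nccc(-c2c(-c3cccc(F)c3)nc3sccn23)n1)c1ccc(Cl)cc1` differs from compound 2 by (((4-chlorophenyl)sulfonyl)amino)methyl in place of ((4-chlorophenyl)sulfonyl)amino on a saturated chain carbon, two bonds along the chain from a nitrogen on an aromatic ring. Among the measured compounds shown here, the one measured step that bears on this change runs the other way: an at least 1.0-fold lower number from compound 1 to compound 2 (0.03 log units; that floor lies within the scatter), where the shorter chain arrives together with the 4-chlorophenyl group while the longer chain and the 4-fluorophenyl group leave. Read in reverse, lengthening the chain is expected to leave the number where it is or move it somewhat higher, back toward the limit. Compound 3 is therefore expected to give about 25000 nM, within a range from 12000 nM to 60000 nM, an estimated step of a 1.3-fold higher number from compound 2 to compound 3 (0.13 log units; within the scatter) that would lie within the scatter, with a fair chance that only a limit is reported.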

Compound 3, half-maximal inhibitory concentration: 8450 nM
Compound 3: middle estimate off by 3.0-fold (0.47 log units), on the high side; the measured number lies below the stated range.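

With the 4-chlorophenyl group held fixed, (((4-chlorophenyl)sulfonyl)amino)methyl in place of ((4-chlorophenyl)sulfonyl)amino gives a 2.2-fold lower number from compound 2 to compound 3 (0.34 log units; beyond the scatter) in this assay, so the change on the chain is now seen apart from any change on the aromatic ring. With the longer chain held fixed, chloro in place of fluoro on an aromatic carbon gives an at least 2.3-fold lower number from compound 1 to compound 3 (0.37 log units; beyond the scatter), so the change of halogen is also seen on its own. That second step is only a floor, as the value of compound 1 is a limit and not a number: the limit of > 20000 nM in this assay, at which 1 of the 3 values shown sits.

Going by these compounds, each change rests on a single pair, so it remains open whether the chain step holds with a fluoro group in place of chloro. A longer chain, or a bromo or methoxy group in place of chloro, could move the number either way.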